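The source may hold more compounds than are shown below. What is called first, only, known or untested is meant among the compounds shown, and "the series" means these compounds.

Of the compounds shown here, three that share one core have been measured in an assay on 32D cells for inhibition of interleukin-15 (Mus musculus), read by resazurin assay, with stated times of 30 min and 2.5 days, in the presence of a further agent that is not named here; a lower number here means a stronger inhibitor, a higher number a weaker inhibitor. Compound 1 `CCOC(CCn1c(Cc2nn(C)c(=O)c3ccccc23)nnc1SCC(=O)Nc1ccc(Cl)cc1Cl)OCC` gives > 30000 nM in this assay, which is a limit of the assay and not a number. Compound 2 `Cn1nc(Cc2nnc(SCCCCCCCC(=O)Nc3ccc(Cl)cc3Cl)n2CCCO[Si](C)(C)C(C)(C)C)c2ccccc2c1=O` gives > 30000 nM in this assay, again only a limit. Compound 3 `Cn1c(Cc2nn(CCC3OCCO3)c(=O)c3ccccc23)nnc1SCC(=O)Nc1ccc(Cl)cc1Cl` gives > 30000 nM in this assay, once more a limit. Compound 3 therefore stands exactly where the other two stand: every value shown sits at the same limit (the limit of > 30000 nM in this assay, at which 3 of the 3 values shown sit), and no number separates any of them.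

Compound 4 `CN(C)CCCn1nc(Cc2nnc(SCC(=O)Nc3ccc(Cl)cc3Cl)n2C)c2ccccc2c1=O` has not yet been measured. It differs from compound 3 in one place: (dimethylamino)methyl in place of 1,3-dioxolan-2-yl on a saturated chain carbon, two bonds along the chain from an aromatic nitrogen. Within the data shown here, no step between two measured compounds exists here to show how far such a change can move the read-out in this assay, so the size of this step can only be guessed. Given that all three measured values rest at the limit (the limit of > 30000 nM in this assay, at which 3 of the 3 values shown sit), the expected step is a number no higher from compound 3 to compound 4 (the limit leaves the size open), that is, none beyond the scatter, with a real chance that this assay again reports only a limit. Compound 4 is estimated at 30000 nM, within a range from 5000 nM to 100000 nM.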

Compound 4, half-maximal inhibitory concentration: 18800 nM
Estimate against measurement, compound 4: 1.6-fold (0.20 log units) above; low and high end bracket the measured number.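

In this assay, putting (dimethylamino)methyl in place of 1,3-dioxolan-2-yl on a saturated chain carbon, two bonds along the chain from an aromatic nitrogen, gives an at least 1.5-fold lower number from compound 3 to compound 4 (0.20 log units; that floor lies within the scatter). From the compounds shown here alone, the value of compound 3, > 30000 nM, is a limit of the assay and not a number, so the true size of this step stays open, and its printed floor alone does not clear the usual scatter. What is new is that this position can carry a group at which the assay returns an actual number, a first for this set, as compound 4 is the only compound shown that does not sit at the limit: the limit of > 30000 nM in this assay, at which 3 of the 4 values shown sit.

This single step swaps a ring with two oxygens for an open chain ending in an amine, so the compounds shown cannot tell whether the amine nitrogen or the loss of the ring matters more. How the read-out would respond at this position to a shorter 2-(dimethylamino)ethyl group, a longer chain ending in the same amine, a ring amine such as morpholine, or a carboxylic acid remains an open question.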